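Triazole-linked chalcones tested for growth inhibition in breast cancer cells

The compounds below may be only part of what the source reports. "The series", "measured", "known", "first", "only" and "open" are said of these compounds alone.

Three compounds share one core and were tested in a functional assay on MCF7 cells (Homo sapiens) for inhibition, read by MTT assay, with a stated time of 48 h, tested at 10 uM; on this read-out lower numbers stand for less inhibition of growth and higher numbers for more inhibition of growth at the one concentration tested. Compound 1 `O=C(/C=C/c1ccc(OCc2cn(Cc3ccc(Br)cc3)nn2)cc1)c1ccc(Br)cc1` gives 23%. Compound 2 `O=C(/C=C/c1ccc(OCc2cn(Cc3ccccc3F)nn2)cc1)c1ccc(Br)cc1` gives 38%. Compound 3 `O=C(/C=C/c1ccc(OCc2cn(Cc3ccc(Br)cc3)nn2)cc1)c1ccc([N+](=O)[O-])cc1` gives 18%, the lowest of the three numbers, though its gap to compound 1 lies within the scatter.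

One change has already been measured once: 2-fluorophenyl in place of 4-bromophenyl on a saturated chain carbon bound to an aromatic nitrogen. This gave a number 15 percentage points higher from compound 1 to compound 2 (beyond the scatter). The cores of compound 1 and compound 3 differ in another way: nitro in place of bromo on an aromatic carbon. That change gave a number 5 percentage points lower from compound 1 to compound 3 (within the scatter).

Compound 4 `O=C(/C=C/c1ccc(OCc2cn(Cc3ccccc3F)nn2)cc1)c1ccc([N+](=O)[O-])cc1` has not been measured. It differs from compound 3 in the same way that compound 2 differs from compound 1, at the same place: 2-fluorophenyl in place of 4-bromophenyl on a saturated chain carbon bound to an aromatic nitrogen. Because the earlier step was a number 15 percentage points higher from compound 1 to compound 2 (beyond the scatter), a step of about the same size is expected in this assay, namely a number 15 percentage points higher from compound 3 to compound 4 (beyond the scatter). Whether the change carries over onto the core of compound 3 rests on a single prior example, so the range is kept wide. Compound 4 is thus estimated at 33%, with an expected span from 18% to 48%.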

Compound 4, percent growth inhibition at one concentration: 33%
For compound 4 middle estimate and measured number coincide at the digits printed; the measured number falls inside the stated range.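

In this assay, 2-fluorophenyl in place of 4-bromophenyl on the core of compound 3 gave a number 15 percentage points higher from compound 3 to compound 4 (beyond the scatter), so this change carried over between the two cores with its size intact: the same change on two cores in this assay, a number 15 percentage points higher (beyond the scatter) from compound 1 to compound 2 and a number 15 percentage points higher (beyond the scatter) from compound 3 to compound 4, 0 percentage points apart, within the scatter of two such steps. Nitro in place of bromo on an aromatic carbon, read on the other pair, gave a number 5 percentage points lower from compound 2 to compound 4 (within the scatter), and it too repeated, though as a step that cannot be told from the scatter on either core: the same change on two cores in this assay, a number 5 percentage points lower (within the scatter) from compound 1 to compound 3 and a number 5 percentage points lower (within the scatter) from compound 2 to compound 4, 0 percentage points apart, within the scatter of two such steps. This agreement rests on two cores and one pair of groups at each place, so it shows that the two changes behaved alike within this small square of compounds, but it does not show that they would do so on any further core, nor does it explain why the number rises.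

The compounds shown leave open what an amine or a carboxylic acid would give in place of bromo or nitro on that aromatic carbon. They also leave open whether a longer chain or an unsubstituted benzyl in place of the 2-fluorobenzyl would keep the higher number.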